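This account rests on a few compounds, and the source may have more. Where it says the series, first, only, none or still open, it means among the compounds named here.

Measured so far:
compound 1 `COc1cc(-c2nnc(SCc3ccc([N+](=O)[O-])cc3)o2)ccc1O` — 14200 nM
compound 2 `COc1cc(-c2nnc(SCc3cccc(Br)c3)o2)ccc1O` — 48100 nM
compound 3 `COc1cc(-c2nnc(SCc3c(F)cccc3F)o2)ccc1O` — 10100 nM

In a functional assay on cells (T-cell, Mus musculus, strain BALB/c) for inhibition, read by MTT assay, with stated times of 24 h and 72 h (a lower number here means a stronger inhibitor, a higher number a weaker inhibitor), compound 3 holds the lowest of the three numbers. Compound 1 sits within the usual scatter of it, so the two cannot be ranked; compound 2 lies beyond it. Among the compounds with values here, the only single-place step available is a 4.8-fold lower number from compound 2 to compound 3 (0.68 log units; beyond the scatter), and it concerns the same position as the change now at hand. Compound 4 `COc1cccc(CSc2nnc(-c3ccc(O)c(OC)c3)o2)c1` is not yet measured. Relative to compound 3 the difference is 3-methoxyphenyl in place of 2,6-difluorophenyl on a saturated chain carbon bound to a sulfur. Within the data shown here, the three measured groups at this position move the numbers over a modest span, with compound 1 and compound 3 close together and compound 2 higher; no measured compound carries a methoxyphenyl group at this position, so the direction of the step is open. A modest move toward a higher number than compound 3 is expected to be about as likely as no move beyond the scatter. Compound 4 is expected to give 20000 nM, between 8000 nM and 60000 nM. This expectation amounts to a 2.0-fold higher number from compound 3 to compound 4 (0.30 log units; within the scatter).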

Compound 4, half-maximal inhibitory concentration: 7410 nM
Compound 4: the middle estimate sits 2.7-fold (0.43 log units) above what was measured; the whole stated range lies above it.
By their numbers in this assay, from the lowest: compounds 4, 3 and 1 (each within the scatter of the next); then compound 2.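

In this assay the step from the fluorinated ring to the 3-methoxyphenyl group stays within the scatter, a 1.4-fold lower number from compound 3 to compound 4 (0.13 log units; within the scatter), so the low end of the series at this position is not tied to fluorine or to the 2,6-difluorophenyl pattern. The second step, a 6.5-fold lower number from compound 2 to compound 4 (0.81 log units; beyond the scatter), lies beyond the scatter and shows that the group on the aromatic carbon matters even when the ring keeps the same substitution place, since methoxy and bromo there give clearly different numbers. No measured property of these compounds bears on the reason for this difference.

The compounds shown leave open whether an amine or a carboxylic acid on this ring would fit the same low range. They also leave open whether a longer chain between the sulfur and the ring would hold it.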